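A Chain Hydroxy Swapped for Dimethylamino: Expected Antagonism

The source may hold more compounds than are shown below. What is called first, only, known or untested is meant among the compounds shown, and "the series" means these compounds.

Of the compounds shown here, two have so far been measured in an assay on C6 cells for antagonist activity at prostaglandin E2 receptor EP2 subtype (Homo sapiens), read by TR-FRET, with stated times of 10 min and 40 min, tested at 1 uM; on this read-out lower numbers stand for stronger inhibition and higher numbers for weaker inhibition. Compound 1 `COc1cc(C(N)CC(=O)NCCn2c(C)cc3ccccc32)cc(OC)c1OC` gives 410 nM in this assay. Compound 2 `Cc1cc2ccccc2n1CCNC(=O)/C=C/c1ccc(OCCCO)cc1` gives 11.8 nM in this assay, the lower of the two numbers, and the gap that separates it from compound 1 lies beyond the usual scatter of repeated measurements.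

Compound 3 `Cc1cc2ccccc2n1CCNC(=O)/C=C/c1ccc(OCCCN(C)C)cc1` has not yet been measured. It differs from compound 2 in a single respect: dimethylamino in place of hydroxy on a saturated chain carbon, three bonds along the chain from an oxygen on an aromatic ring. For the measured compounds named here, no measured pair in this small set isolates this particular change, so any expectation rests only on compound 2 and the nature of the swap. The group that leaves and the group that enters each carry one hydrogen-bond acceptor, while the donor of the hydroxy is lost; the saturated chain and the oxygen on the aromatic ring remain as they stand.

The author expects the step of a 1.0-fold higher number from compound 2 to compound 3 (0.01 log units; within the scatter) to stay within the scatter, with no clear direction. For compound 3 the estimate in this assay is 12 nM, with a range from 3.5 nM to 40 nM.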

Compound 3, antagonist equilibrium constant in the prostaglandin E2 receptor EP2 subtype assay: 74.6 nM
Beside the measured number, compound 3's estimate is 6.2-fold (0.79 log units) below it; measured number outside the range, above it.
By their numbers in the prostaglandin E2 receptor EP2 subtype assay, from the lowest: compound 2; then compound 3; then compound 1.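

For the compounds shown here, until this result no pair isolated a change at this place. In the prostaglandin E2 receptor EP2 subtype assay, dimethylamino in place of hydroxy on a saturated chain carbon, three bonds along the chain from an oxygen on an aromatic ring, gives a 6.3-fold higher number from compound 2 to compound 3 (0.80 log units; beyond the scatter), so this place is not indifferent to the group it carries, and since a higher number stands for weaker inhibition, the swap gives up some antagonist strength. The same swap brings a gain in a physicochemical assay for solubility, read by nephelometry, in phosphate buffer, at pH 7.4 (on this read-out higher numbers stand for higher solubility and lower numbers for lower solubility), since compound 2 gives 66000 nM and compound 3 gives 306000 nM there, with higher numbers standing for higher solubility: the measured solubility of compound 2, 66000 nM, and of compound 3, 306000 nM, a 4.6-fold higher number (0.67 log units; beyond the scatter)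

This single pair cannot tell whether the lost hydrogen-bond donor or the larger entering group accounts for the step in the prostaglandin E2 receptor EP2 subtype assay. Also open, from the compounds shown here alone, is how a methoxy group or a primary amine at the same place, or a longer chain carrying the dimethylamino, would fare on both read-outs, and whether any of them could keep the higher solubility with a smaller step in antagonist strength.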